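Hydroxy for Chloro on a Cytotoxicity Series

This account rests on a few compounds, and the source may have more. Where it says the series, first, only, none or still open, it means among the compounds named here.

Compound 1 `Fc1ccc2nc(-c3ccccc3)nc(Nc3ccccc3)c2c1`: > 50000 nM
Compound 2 `Fc1cccc(-c2nc(Nc3cccc(Cl)c3)c3cc(F)ccc3n2)c1`: > 50000 nM

In a functional assay on U-937 cells (Homo sapiens) for cytotoxicity, read by MTT assay, with a stated time of 48 h (on this read-out higher numbers stand for weaker inhibition and lower numbers for stronger inhibition), compound 1 reaches only the limit of the test, > 50000 nM, not a number. Compound 2 likewise stops at the limit, > 50000 nM. Both values therefore rest at the limit of > 50000 nM in this assay, at which 2 of the 2 values shown sit, so compound 2 stands nowhere distinct from compound 1.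

Compound 3 `Oc1cccc(Nc2nc(-c3cccc(F)c3)nc3ccc(F)cc23)c1` has not been measured. It differs from compound 2 by hydroxy in place of chloro on an aromatic carbon. With both measured compounds at the limit, no step size can be read from them. A step from compound 2 to compound 3 of a number no higher from compound 2 to compound 3 (the limit leaves the size open) is expected, essentially none beyond the scatter. Compound 3 is estimated at 50000 nM, between 15000 nM and 150000 nM, most likely again a limit.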

Compound 3, half-maximal inhibitory concentration: > 50000 nM
Compound 3 gave a limit, no number; the forecaster's own chance of this, stated with the estimate: 75%; the middle value lies on the limit itself.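

Among these compounds, compound 2 and compound 3 each give only a limit, not a number, in this assay, so no step between them can be read. The compounds shown leave open whether hydroxy in place of chloro changes cytotoxicity at all.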